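Exchanging the Ring Pair on the Amine Side Chain

A few compounds are considered here, and "the series" means these few. Any claim that something is new, unique, unknown or untested is made for them only; others in the source may bear on it.

Among the compounds with values here, in an ADME assay on K562 cells (Homo sapiens) for antiproliferative activity (a lower number here means a stronger inhibitor, a higher number a weaker inhibitor), compound 1 `COc1ccc2nccc(CC[C@H]3OC[C@H](NCc4ccc(Cl)cc4)CO3)c2c1` gives 12000 nM and compound 2 `COc1ccc2nccc(CC[C@H]3OC[C@H](NCc4ccc5c(n4)NC(=O)CO5)CO3)c2c1` gives 24000 nM, so compound 2 stands within the scatter of the only other measured compound. Compound 3 `COc1ccc2nccc(CC[C@H]3OC[C@H](NCc4cc5c(cn4)OCCC5)CO3)c2c1` differs from compound 2 by a group of 10 heavy atoms (8 carbon, 1 nitrogen, 1 oxygen; one six-membered non-aromatic ring with 1 hetero atom, one six-membered aromatic ring with 1 hetero atom) in place of a group of 11 heavy atoms (7 carbon, 2 nitrogen, 2 oxygen; one six-membered non-aromatic ring with 2 hetero atoms, one six-membered aromatic ring with 1 hetero atom), on a saturated chain carbon bound to an amine nitrogen. Within the data shown here, the one measured step, a 2.0-fold higher number from compound 1 to compound 2 (0.30 log units; within the scatter), changed the group at this same place and stayed within the scatter. No step beyond the scatter is therefore expected in this assay. The expected change is a 1.5-fold lower number from compound 2 to compound 3 (0.18 log units; within the scatter). Compound 3 is estimated at 16000 nM, with an expected range of 7000 nM to 35000 nM.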

Compound 3, half-maximal inhibitory concentration: 32000 nM
Beside the measured number, compound 3's estimate is 2.0-fold (0.30 log units) below it; the range from low to high includes it.
By their numbers in this assay, from the lowest: compounds 1, 2 and 3 (each within the scatter of the next, the first and the last beyond it).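

In this assay, the group with 0 hydrogen-bond donors took the place of the group with 1 on a saturated chain carbon bound to an amine nitrogen, and this gave a 1.3-fold higher number from compound 2 to compound 3 (0.12 log units; within the scatter) without leaving the scatter. Within the data shown here, exchanging the chlorine-bearing group for the same new group gave a 2.7-fold higher number from compound 1 to compound 3 (0.43 log units; beyond the scatter) as the only step at this place beyond the scatter. Nothing available explains these numbers. From the compounds shown here alone, all three groups hold a six-membered aromatic ring, so it remains open how a group carrying an amine or a carboxylic acid would read here.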